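This account rests on a few compounds, and the source may have more. Where it says the series, first, only, none or still open, it means among the compounds named here.

Working notes on the acetophenone-derived series.

Compound 1 `CCc1cc(C(C)=O)c(O)cc1OCCCCC#N` gives 57% in an assay on isolated protein for binding affinity to leukotriene B4 receptor 1 (Homo sapiens), tested at 1 uM; on this read-out higher numbers stand for more inhibition at the one concentration tested (going by the name of the read-out) and lower numbers for less inhibition. Compound 2 `CCc1cc(C(C)=O)c(O)cc1OCCCCCCC#N` gives 73% in this assay, and the step of a number 16 percentage points higher from compound 1 to compound 2 (beyond the scatter) follows the change (2-cyanoethyl in place of cyano on a saturated chain carbon, four bonds along the chain from an oxygen on an aromatic ring).

Compound 3 `C=CCc1cc(C(C)=O)c(O)cc1OCCCCCCCCC#N` gives 50% in this assay. The difference between the core of compound 3 and the core of compound 1 is not broken down here; their two values sit within the scatter of each other, while compound 2 stands beyond the scatter above compound 3.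

Compound 4 `C=CCc1cc(C(C)=O)c(O)cc1OCCCCCCCCCCC#N` is not yet measured in this assay. It differs from compound 3 by 2-cyanoethyl in place of cyano on a saturated chain carbon, eight bonds along the chain from an oxygen on an aromatic ring. This is the same kind of change as that from compound 1 to compound 2, but not the same: there the place was four bonds along the chain from an oxygen on an aromatic ring, here it is eight bonds along the chain from that oxygen.

For compound 4 a step of about a number 8 percentage points higher from compound 3 to compound 4 (within the scatter) is expected, resting on the earlier step of a number 16 percentage points higher from compound 1 to compound 2 (beyond the scatter), tempered since the place is further out and the core of compound 3 is a different one. Compound 4 is therefore estimated at 58% in this assay, expected between 40% and 75%.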

Compound 4, a percentage reported as inhibition, at one concentration (the size of the read-out at that concentration, not a potency): 14%
For compound 4 the middle estimate is 44 percentage points above the measured one, outside the stated range (below it).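

In this assay the same change goes with a number 36 percentage points lower from compound 3 to compound 4 (beyond the scatter), so its direction on the core of compound 1 does not carry over to the core of compound 3. The two steps differ in direction and size: the same change on two cores in this assay, a number 16 percentage points higher (beyond the scatter) from compound 1 to compound 2 and a number 36 percentage points lower (beyond the scatter) from compound 3 to compound 4, 52 percentage points apart, beyond the scatter of two such steps

This does not show which difference matters, as the two steps differ at once in the core and in the place of the change, four bonds along the chain from an oxygen on an aromatic ring in one and eight bonds in the other, and the compounds shown do not separate the two.

Open, going by these compounds, is how the change behaves at the same place on both cores, which would separate the core from the place. Also open, on these data alone, is whether a longer chain on either core, or a carboxylic acid or an amine in place of the nitrile, would follow the same course in this assay.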